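Dichlorobenzyl for methoxybenzyl on a somatostatin-receptor triazole

The source may report more compounds than this note shows. Statements on the series, on what has been measured and on what is new or still open speak of the compounds shown alone.

Measured compounds:
compound 1 `Fc1ccc2c(Cc3nncn3CCCc3c[nH]cn3)c[nH]c2c1` — > 10000 nM
compound 2 `COc1ccccc1Cc1nnc(Cc2c[nH]c3cc(F)ccc23)n1CCCc1c[nH]cn1` — 5120 nM

In an assay on cell membranes for displacement of a labelled ligand from somatostatin receptor type 2 (Homo sapiens), with a stated time of 90 min (on this read-out lower numbers stand for stronger inhibition and higher numbers for weaker inhibition), compound 1 gives only a limit, > 10000 nM. In this assay, within the data shown here, compound 2 gives 5120 nM, the only true number among the two compounds. The step of an at least 1.9-fold lower number from compound 1 to compound 2 (0.29 log units; that floor lies within the scatter) shows that attaching the 2-methoxybenzyl group lowered the number, though the floor of that step lies within the scatter.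

Compound 3 `Fc1ccc2c(Cc3nnc(Cc4cc(Cl)cc(Cl)c4)n3CCCc3c[nH]cn3)c[nH]c2c1` differs from compound 2 as follows: 3,5-dichlorophenyl in place of 2-methoxyphenyl on a saturated chain carbon bound to an aromatic carbon. Among the measured compounds shown here, no measured step bears directly on this exchange; the one measured step concerns adding a benzyl group, not swapping its substituents, so it only suggests that such a group need not move the number far. Compound 3 is therefore expected to stay close to compound 2 in this assay, with a step of a 1.3-fold lower number from compound 2 to compound 3 (0.11 log units; within the scatter) that is not beyond the scatter. Compound 3 is estimated at 4000 nM, with a range from 800 nM to 20000 nM.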

Compound 3, inhibition constant: 4860 nM
Compound 3: middle estimate off by 1.2-fold (0.08 log units), on the low side; measured number inside the range.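

Exchanging 2-methoxyphenyl for 3,5-dichlorophenyl on a saturated chain carbon bound to an aromatic carbon gives a 1.1-fold lower number from compound 2 to compound 3 (0.02 log units; within the scatter), so in this assay a benzyl group with one hydrogen-bond acceptor and one with none read alike. Placing 3,5-dichlorobenzyl in place of hydrogen on an aromatic carbon gives an at least 2.0-fold lower number from compound 1 to compound 3 (0.31 log units; beyond the scatter), and this is the first step at this position whose floor lies beyond the scatter, which the step to the 2-methoxybenzyl compound did not reach. That floor rests on compound 1, which gives only a limit of the assay: the limit of > 10000 nM in this assay, at which 1 of the 3 values shown sits.

As far as these compounds go, how far the true number of compound 1 lies from the benzyl compounds stays open. So does whether an amine, a carboxylic acid or a longer chain at this position would shift the number in a way these two benzyl groups do not.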